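Fluoro-to-chloro swap on the benzyl ring, dibromo core

The source may report more compounds than this note shows. Statements on the series, on what has been measured and on what is new or still open speak of the compounds shown alone.

In a functional assay on MCF7 cells (Homo sapiens) for antiproliferative activity, read by MTT assay, with a stated time of 48 h (a higher number here means a weaker inhibitor, a lower number a stronger inhibitor), compound 1 `O=[N+]([O-])c1cc(C(F)(F)F)cc([N+](=O)[O-])c1Oc1ccc(Cl)cc1/C=N\OCc1ccccc1F` gives 1110 nM. Compound 2 `O=[N+]([O-])c1cc(C(F)(F)F)cc([N+](=O)[O-])c1Oc1ccc(Cl)cc1/C=N\OCc1ccccc1Cl`, which carries the change (chloro in place of fluoro on an aromatic carbon), gives 3950 nM in this assay. For the measured compounds named here, the step of a 3.6-fold higher number from compound 1 to compound 2 (0.55 log units; beyond the scatter) is the only measured instance of this change in the set.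

Compound 3 `O=[N+]([O-])c1cc(C(F)(F)F)cc([N+](=O)[O-])c1Oc1c(Br)cc(Br)cc1/C=N\OCc1ccccc1F` rests on a different core; the difference between the two cores is not broken down here. In this assay compound 3 gives 880 nM, which stands close to compound 1 and clearly apart from compound 2.

Compound 4 `O=[N+]([O-])c1cc(C(F)(F)F)cc([N+](=O)[O-])c1Oc1c(Br)cc(Br)cc1/C=N\OCc1ccccc1Cl` is not yet measured in this assay. It differs from compound 3 by chloro in place of fluoro on an aromatic carbon, and the place of the change is the same as that of the change from compound 1 to compound 2, so the two changes are the same change on two cores.

The expectation for compound 4 therefore rests on compound 2, whose step from compound 1 was a 3.6-fold higher number from compound 1 to compound 2 (0.55 log units; beyond the scatter) in this assay. Going by the values given here, with only one measured instance of this change, the transfer to the other core is uncertain, and the range is set wide. The expected step is a 3.5-fold higher number from compound 3 to compound 4 (0.55 log units; beyond the scatter) in this assay. Compound 4 is estimated at 3100 nM in this assay, with the expectation spanning 1300 nM to 7500 nM.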

Compound 4, half-maximal inhibitory concentration: 2320 nM
Compound 4: the middle estimate sits 1.3-fold (0.13 log units) above what was measured; the range from low to high includes it.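

In this assay, the change from 2-fluorobenzyl to 2-chlorobenzyl on the second core gives a 2.6-fold higher number from compound 3 to compound 4 (0.42 log units; beyond the scatter), so the higher number seen on the first core recurs. The size of the step also carries over between the two cores, with no difference that can be separated from scatter: the same change on two cores in this assay, a 3.6-fold higher number (0.55 log units; beyond the scatter) from compound 1 to compound 2 and a 2.6-fold higher number (0.42 log units; beyond the scatter) from compound 3 to compound 4, 1.3-fold (0.13 log units) apart, within the scatter of two such steps. For the compounds shown here, this is still only two matched pairs, with one halogen swap in one place, read in one cell assay, so it supports transfer between these two cores only and shows neither how the change behaves on any other core nor what underlies it.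

The compounds shown leave open how the unsubstituted benzyl group, or a bromo, methoxy or aminomethyl group in the same place on the ring, would read in this assay, and so whether fluoro and chloro are two points on a wider trend or an isolated pair. Also open, on these data alone, is whether the step would hold if the trifluoromethyl or nitro groups of the shared diaryl ether part gave way to a nitrile or a carboxylic acid.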